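The compounds below may be only part of what the source reports. "The series", "measured", "known", "first", "only" and "open" are said of these compounds alone.

Compound 2 `COc1cc(N/C(CCNC2=CC(=O)c3ccccc3C2=O)=N\S(=O)(=O)c2ccc(C)cc2)cc(OC)c1OC` stands at the lower of the two numbers recorded in a functional assay on HeLa cells (Homo sapiens) for cytotoxicity, read by MTT assay, with a stated time of 48 h (on this read-out lower numbers stand for stronger inhibition and higher numbers for weaker inhibition), where compound 2 gives 3390 nM. Going by the values given here, compound 1 `Cc1ccc(S(=O)(=O)/N=C(/CCNC2=CC(=O)c3ccccc3C2=O)Nc2ccc(F)c(F)c2)cc1` gives 8790 nM in this assay, and the single counted step, a 2.6-fold lower number from compound 1 to compound 2 (0.41 log units; beyond the scatter), came from a 3,4,5-trimethoxyphenyl replacing a 3,4-difluorophenyl on the amine nitrogen. Compound 3 `Cc1ccc(S(=O)(=O)/N=C(/CCNC2=CC(=O)c3ccccc3C2=O)NC2CCCCC2)cc1` is not yet measured; it differs from compound 2 by cyclohexyl in place of 3,4,5-trimethoxyphenyl on an amine nitrogen, a cyclohexyl taking the place of the 3,4,5-trimethoxyphenyl on the amine nitrogen whose other neighbour is a carbon with a double bond to nitrogen. Among the compounds with values here, no measured step exchanges an aromatic ring for a non-aromatic one at this position, so the only guide is that changing the group on this nitrogen has so far moved the number modestly. The step expected here is a 1.9-fold higher number from compound 2 to compound 3 (0.28 log units; within the scatter), a modest rise. Compound 3 is therefore estimated at 6500 nM in this assay, within a range of 2500 nM to 17000 nM.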

Compound 3, half-maximal inhibitory concentration: 9770 nM
Compound 3: the middle estimate sits 1.5-fold (0.18 log units) below what was measured; low and high end bracket the measured number.
By their numbers in this assay, from the lowest: compound 2; then compounds 1 and 3 (each within the scatter of the next).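

In this assay, cyclohexyl on the amine nitrogen brings the first non-aromatic ring to this position, and replacing the 3,4,5-trimethoxyphenyl with it gives a 2.9-fold higher number from compound 2 to compound 3 (0.46 log units; beyond the scatter) as the result. Replacing the 3,4-difluorophenyl with the same cyclohexyl gives a 1.1-fold higher number from compound 1 to compound 3 (0.05 log units; within the scatter), so having an aromatic ring at this position does not by itself set a compound apart, and among these three groups only the 3,4,5-trimethoxyphenyl stands apart. Nothing available explains this difference.

On these data alone, it remains open whether the methoxy groups account for the lower number, which an unsubstituted phenyl or a phenyl with a single methoxy could test. Also open, as far as these compounds go, is whether an open chain such as butyl or a smaller ring such as cyclopropyl would match cyclohexyl.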